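A few compounds are considered here, and "the series" means these few. Any claim that something is new, unique, unknown or untested is made for them only; others in the source may bear on it.

Measured so far in a functional assay on PC-3 cells (Homo sapiens) for antiproliferative activity, read by MTT assay; on this read-out lower numbers stand for stronger inhibition and higher numbers for weaker inhibition:
compound 1 `Cn1c(=O)c(=O)n(C2CCCC2)c2nc(N/N=C/c3ccc(O)cc3)ncc21`: > 100000 nM
compound 2 `Cn1c(=O)c(=O)n(C2CCCC2)c2nc(N/N=C/c3ccc(S(C)(=O)=O)cc3)ncc21`: 26600 nM.

Compound 1 has the value > 100000 nM, which is a limit of this assay and not a number, so compound 1 stands at the limit of > 100000 nM in this assay, at which 1 of the 2 values shown sits, with only a range known for it. For the measured compounds named here, the single measured step, an at least 3.7-fold lower number from compound 1 to compound 2 (0.57 log units; beyond the scatter), runs from that limit to a number and is therefore itself only a lower bound on the change. Compound 3 `Cn1c(=O)c(=O)n(C2CCCC2)c2nc(N/N=C/c3ccc(C(F)(F)F)cc3)ncc21` differs from compound 1 by trifluoromethyl in place of hydroxy on an aromatic carbon. Going by the values given here, both the measured step and this one replace the hydroxy on the aromatic carbon with a group that carries no hydrogen-bond donor, so the step from compound 1 to compound 2 is the only guide available; it was at least modest and downward. The same direction is expected for compound 3, with the size uncertain, as an at least 2.8-fold lower number from compound 1 to compound 3 (0.45 log units; beyond the scatter). Compound 3 is accordingly estimated at 35000 nM, in the range 9000 nM to 130000 nM, with a real chance that only a limit is reported.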

Compound 3, half-maximal inhibitory concentration: 23600 nM
Estimate against measurement, compound 3: 1.5-fold (0.17 log units) above; the measured number falls inside the stated range.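

In this assay, a second replacement of the hydroxy on the aromatic carbon para to a large group gives an at least 4.2-fold lower number from compound 1 to compound 3 (0.62 log units; beyond the scatter), so the downward step no longer rests on methylsulfonyl alone. The two replacements can now be compared directly, and a 1.1-fold lower number from compound 2 to compound 3 (0.05 log units; within the scatter) leaves trifluoromethyl and methylsulfonyl indistinguishable at this position. Compound 1 stands at a limit of the assay and not a number, and the size of any step away from hydroxy remains only a lower bound: the limit of > 100000 nM in this assay, at which 1 of the 3 values shown sits.

On these data alone, what an amine, a carboxylic acid or a longer chain on this carbon would do to the number remains open, as does whether any group here can reach far below the values of compound 2 and compound 3. Also open, as far as these compounds go, is whether the match between methylsulfonyl and trifluoromethyl holds with these groups elsewhere on the ring.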